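The source may hold more compounds than are shown below. What is called first, only, known or untested is meant among the compounds shown, and "the series" means these compounds.

Of the compounds shown here, two sharing one core have been measured in an assay on HT-29 cells for inhibition of Serine-protein kinase ATM (Homo sapiens), read by fluorescence, with a stated time of 1 h; on this read-out lower numbers stand for stronger inhibition and higher numbers for weaker inhibition. Compound 1 `CCC(CC)CNc1c(C(N)=O)cnc2ccc(-c3cccnc3)cc12` gives 73 nM, and compound 2 `NC(=O)c1cnc2ccc(-c3cccnc3)cc2c1SC1CCCC1` gives 9700 nM. Going by the values given here, the one measured step between them, a 130-fold higher number from compound 1 to compound 2 (2.12 log units; beyond the scatter), came with cyclopentylsulfanyl in place of (2-ethylbutyl)amino on an aromatic carbon. Compound 2 thus stands at the highest of the two numbers; its nearest neighbour is compound 1, and the gap between them lies beyond the scatter.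

Compound 3 `C[C@@H](Nc1c(C(N)=O)cnc2ccc(-c3cccnc3)cc12)C1CCOCC1` differs from compound 2 in one place: (1-(oxan-4-yl)ethyl)amino in place of cyclopentylsulfanyl on an aromatic carbon. Among the compounds with values here, the entering group is an amino-linked group, as in compound 1, so the only measured step that bears on this change is a 130-fold higher number from compound 1 to compound 2 (2.12 log units; beyond the scatter); it was large and ran from amino to sulfanyl. Compound 3 runs the other way, so a large drop in this assay is expected for compound 3, although the (1-(oxan-4-yl)ethyl)amino group is not the same as the (2-ethylbutyl)amino group and the size of the step is uncertain. Compound 3 is therefore estimated at 100 nM, within 30 nM to 400 nM. That estimate amounts to an expected step of a 97-fold lower number from compound 2 to compound 3 (1.99 log units; beyond the scatter).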

Compound 3, half-maximal inhibitory concentration: 730 nM
Compound 3: the middle estimate sits 7.3-fold (0.86 log units) below what was measured; the whole stated range lies below it.
By their numbers in this assay, from the lowest: compound 1; then compound 3; then compound 2.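

Going by these compounds alone, compound 3 keeps the nitrogen link of compound 1 and changes only the group carried on that nitrogen, so for the first time this position is probed without leaving the amino link, and in this assay this change gives a 10-fold higher number from compound 1 to compound 3 (1.00 log units; beyond the scatter), a modest step that is still beyond the scatter. The replacement of cyclopentylsulfanyl by (1-(oxan-4-yl)ethyl)amino, on the aromatic carbon opposite the ring nitrogen, gives a 13-fold lower number from compound 2 to compound 3 (1.12 log units; beyond the scatter), so both amino-linked compounds now read lower than the sulfanyl compound 2, with no compound shown going against this, while the nitrogen link alone does not fix the number, as compound 1 and compound 3 remain apart. No measurement shown here accounts for either of these steps.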